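This account rests on a few compounds, and the source may have more. Where it says the series, first, only, none or still open, it means among the compounds named here.

Measured so far:
compound 1 `Cc1ccc2ncc(S(=O)(=O)c3ccc(Cl)cc3)c(N3CCC(C)CC3)c2c1` — 79%
compound 2 `CC1CCN(c2c(S(=O)(=O)c3ccc(Cl)cc3)cnc3ccc(Cl)cc23)CC1` — 92%

In an assay on isolated protein for displacement of a labelled ligand from metabotropic glutamate receptor 5 (Homo sapiens), with a stated time of 60 min, tested at 1 uM (a lower number here means less inhibition, a higher number more inhibition at the concentration tested (going by the name of the read-out)), compound 1 gives 79%, the lowest of the two numbers. Compound 2 gives 92%, and the step of a number 13 percentage points higher from compound 1 to compound 2 (beyond the scatter) comes with chloro in place of methyl on an aromatic carbon. Compound 3 `Cc1ccc2ncc(S(=O)(=O)c3ccc(F)c(Cl)c3)c(N3CCC(C)CC3)c2c1` differs from compound 1 by 3-chloro-4-fluorophenyl in place of 4-chlorophenyl on a sulfonyl sulfur. For the measured compounds named here, the only measured step lies at another part of the shared core, so it gives no direct guide to a change on the sulfonyl sulfur. For compound 3 the expected step is a number 1 percentage points lower from compound 1 to compound 3 (within the scatter), within the scatter. The estimate for compound 3 is 78%, between 60% and 92%.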

Compound 3, a percentage reported as inhibition, at one concentration (the size of the read-out at that concentration, not a potency): 93%
The estimate for compound 3 lay 15 percentage points below the measured number, and the stated range ends below it.
By their numbers in this assay, from the lowest: compound 1; then compounds 2 and 3 (each within the scatter of the next).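

In this assay the aromatic group on the sulfonyl sulfur proves able to move the number: 3-chloro-4-fluorophenyl in place of 4-chlorophenyl gives a number 14 percentage points higher from compound 1 to compound 3 (beyond the scatter), a step beyond the scatter. Until this result, the only step seen lay at another part of the shared core, so this position had shown no effect of its own. No measurement available explains why the number rises.

Going by these compounds, whether 3-chlorophenyl or 4-fluorophenyl alone would give the same step remains open. So does how a methoxy group or an amine on that ring would read.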